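Hydroxy in place of methyl on the shared core

A few compounds are considered here, and "the series" means these few. Any claim that something is new, unique, unknown or untested is made for them only; others in the source may bear on it.

- compound 1 `O=c1ccc(=O)c2c1c1[nH]c3ccccc3c1c1c(=O)[nH]c(=O)c21`: 17400 nM
- compound 2 `Cc1ccc2[nH]c3c4c(=O)ccc(=O)c4c4c(=O)[nH]c(=O)c4c3c2c1`: 20600 nM
- compound 3 `O=c1ccc(=O)c2c1c1[nH]c3ccc(O)cc3c1c1c(=O)[nH]c(=O)c21`: not yet measured

In a functional assay on HT-29 cells (Homo sapiens) for antiproliferative activity, with a stated time of 4 h (on this read-out higher numbers stand for weaker inhibition and lower numbers for stronger inhibition), compound 2 stands level with compound 1, their two values lying within the scatter of each other. The next change puts hydroxy in place of methyl on an aromatic carbon, leading to compound 3: hydroxy in place of methyl on an aromatic carbon. Among the compounds with values here, the only measured step that bears on it is a 1.2-fold higher number from compound 1 to compound 2 (0.07 log units; within the scatter), which stays within the scatter. Within the data shown here, no measured compound carries hydroxy, so the expectation is weakly founded, but no step beyond the scatter is expected in this assay. The estimated change is a 1.3-fold lower number from compound 2 to compound 3 (0.11 log units; within the scatter). Compound 3 is expected at 16000 nM, with an estimated range of 6000 nM to 40000 nM.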

Compound 3, half-maximal inhibitory concentration: 50600 nM
Compound 3: middle estimate off by 3.2-fold (0.50 log units), on the low side, outside the stated range (above it).
By their numbers in this assay, from the lowest: compounds 1 and 2 (each within the scatter of the next); then compound 3.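

In this assay this position on the shared core proves sensitive to the group placed there: hydroxy in place of methyl gives a 2.5-fold higher number from compound 2 to compound 3 (0.39 log units; beyond the scatter) and hydroxy in place of hydrogen gives a 2.9-fold higher number from compound 1 to compound 3 (0.46 log units; beyond the scatter) and both steps lie beyond the scatter. Methyl at the same aromatic carbon had produced no such step, so the outcome here depends on the group that enters. Nothing available accounts for the difference between hydroxy and methyl. Still open, going by these compounds, is whether methoxy or an amine at this position would track hydroxy or methyl. A carboxylic acid there is equally unresolved.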